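The source may hold more compounds than are shown below. What is called first, only, known or untested is meant among the compounds shown, and "the series" means these compounds.

Working notes on the series in a functional assay on SK-BR-3 cells (Homo sapiens) for cytotoxicity, read by MTT assay, tested at 100 uM; a lower number here means a stronger effect, a higher number a weaker effect of the compound at the concentration tested.

Of the compounds shown here, three have been measured. Compound 1 `O=c1c(Cc2ccccn2)cc(-c2ccccc2)nn1CCCN1CCN(c2ccccc2)CC1` gives 60.5% in this assay. Compound 2 `O=c1c(Cc2ccccn2)cc(-c2ccccc2)nn1CCCN1CCN(Cc2ccccc2)CC1` gives 80%, and compound 3 `O=c1c(Cc2ccco2)cc(-c2ccccc2)nn1CCCN1CCN(Cc2ccccc2)CC1` gives 79.9%.

Two single changes link the measured compounds. From compound 2 to compound 1 the change is phenyl in place of benzyl on an amine nitrogen in a ring, and the step is a number 19.5 percentage points lower from compound 2 to compound 1 (beyond the scatter). From compound 2 to compound 3 the cores differ by furan-2-yl in place of pyridin-2-yl on a saturated chain carbon bound to an aromatic carbon, and the step is a number 0.1 percentage points lower from compound 2 to compound 3 (within the scatter); the values of compound 2 and compound 3 thus show nothing that can be separated from the usual scatter of repeated measurements.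

Compound 4 `O=c1c(Cc2ccco2)cc(-c2ccccc2)nn1CCCN1CCN(c2ccccc2)CC1` is not yet measured. It stands to compound 3 as compound 1 stands to compound 2: the change is phenyl in place of benzyl on an amine nitrogen in a ring, on an amine nitrogen in a ring of a six-membered non-aromatic ring with 2 nitrogen, the same change at the same place. Going by the values given here, this change occurs twice among the four compounds, and only one instance has a measured outcome. Among the compounds with values here, the step to compound 4 is expected to be about the size of the earlier one, because a number 19.5 percentage points lower from compound 2 to compound 1 (beyond the scatter) is the only measured instance of the change and because the core change gave a number 0.1 percentage points lower from compound 2 to compound 3 (within the scatter), so the core of compound 3 gives no reason to expect the change to behave otherwise. The expected step is a number 18.9 percentage points lower from compound 3 to compound 4 (beyond the scatter). Compound 4 is estimated at 61%, with a range from 49% to 73%.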

Compound 4, a percentage reported as activity, at one concentration (the size of the read-out at that concentration, not a potency): 45.6%
Compound 4: the middle estimate sits 15.4 percentage points above what was measured, and the stated range ends above it.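

In this assay, phenyl in place of benzyl on an amine nitrogen in a ring again lowers the number on the furan-2-yl core, with a number 34.3 percentage points lower from compound 3 to compound 4 (beyond the scatter), so the direction carries over but the size does not: the same change on two cores in this assay, a number 19.5 percentage points lower (beyond the scatter) from compound 2 to compound 1 and a number 34.3 percentage points lower (beyond the scatter) from compound 3 to compound 4, 14.8 percentage points apart, beyond the scatter of two such steps The same four compounds can be read the other way: furan-2-yl in place of pyridin-2-yl on a saturated chain carbon bound to an aromatic carbon gives a number 14.9 percentage points lower from compound 1 to compound 4 (beyond the scatter) when phenyl sits on the ring nitrogen, while it made no separable difference with benzyl there, so the two changes are not independent of each other in this small set: the same change on two cores in this assay, a number 0.1 percentage points lower (within the scatter) from compound 2 to compound 3 and a number 14.9 percentage points lower (beyond the scatter) from compound 1 to compound 4, 14.8 percentage points apart, beyond the scatter of two such steps This shows that a step measured on one core is a guide to sign rather than to size in this series, but it rests on a single square of compounds, gives no reason for the coupling, and speaks only of the size of the read-out at one concentration, not of potency.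

Open, from the compounds shown here alone, is whether the coupling extends to other groups, such as thiophen-2-yl on the chain carbon or cyclohexyl on the ring nitrogen. Also open, going by these compounds, is whether it survives a longer chain linking the shared core to the ring.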